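Swapping the phenyl on the triazole for a fluorophenyl-amide chain

The compounds below may be only part of what the source reports. "The series", "measured", "known", "first", "only" and "open" are said of these compounds alone.

Compounds measured so far in a functional assay on HeLa cells (Homo sapiens) for inhibition, read by MTT assay, with a stated time of 24 h; on this read-out higher numbers stand for weaker inhibition and lower numbers for stronger inhibition:
- compound 1, `CCOC(=O)C1=Cc2ccccc2OC1(OCc1cn(-c2ccc(F)cc2)nn1)C(F)(F)F`: 8400 nM
- compound 2, `CCOC(=O)C1=Cc2ccccc2OC1(OCc1cn(-c2ccccc2)nn1)C(F)(F)F`: > 150000 nM

Compound 2 did not reach a number in this assay; its value of > 150000 nM is only a limit of the measurement (the limit of > 150000 nM in this assay, at which 1 of the 2 values shown sits). Compound 3, `CCOC(=O)C1=Cc2ccccc2OC1(OCc1cn(CC(=O)Nc2cccc(F)c2)nn1)C(F)(F)F`, has not yet been measured. It differs from compound 2 in one place: ((3-fluorophenyl)carbamoyl)methyl in place of phenyl on an aromatic nitrogen.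

Among the measured compounds shown here, only one measured step is available, and it bears on this change indirectly: an at least 17-fold higher number from compound 1 to compound 2 (1.25 log units; beyond the scatter). That step shows that a fluorine on the aryl ring attached to the triazole mattered greatly, while compound 2 without it stayed at the limit. Compound 3 brings a fluorine-bearing aromatic ring back, though on a longer chain with an amide, so some return of inhibition is expected, meaning a step of an at least 5.0-fold lower number from compound 2 to compound 3 (0.69 log units; beyond the scatter). The estimate for compound 3 is therefore 30000 nM, with a range from 5000 nM to 150000 nM.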

Compound 3, half-maximal inhibitory concentration: > 150000 nM
Compound 3: no number, only a limit (the forecaster's own chance of this, stated with the estimate: 35%); middle value at least 5.0-fold (0.69 log units) from the limit.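

In this assay, compound 3 gives no number: its > 150000 nM is a limit of the assay. A fluorine on an aromatic ring is therefore not enough on its own at this position, since putting ((3-fluorophenyl)carbamoyl)methyl in place of 4-fluorophenyl on the aromatic nitrogen gives an at least 17-fold higher number from compound 1 to compound 3 (1.25 log units; beyond the scatter). The step between the two compounds without a number cannot be read, as both rest on a limit: the limit of > 150000 nM in this assay, at which 2 of the 3 values shown sit.

The compounds shown leave open whether the amide chain or the place of the fluorine on the ring matters more, as the two change together in this step. Also open, going by these compounds, is how a 3-fluorophenyl attached directly to the aromatic nitrogen, or a 4-fluorophenyl carrying an amine or a carboxylic acid, would behave.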